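Adding a second acetyl to compound 3

The source may report more compounds than this note shows. Statements on the series, on what has been measured and on what is new or still open speak of the compounds shown alone.

Measured in a functional assay on DLD-1 cells (Homo sapiens) for cytotoxicity, read by XTT assay; on this read-out lower numbers stand for stronger inhibition and higher numbers for weaker inhibition:
Compound 1 `C/C(=C\[C@@H](O)C/C(C)=C/CCc1ccoc1)CC[C@@H](O)[C@]1(C)CCC(=O)O1` gives 40 nM
Compound 2 `CC(=O)O[C@H](CC/C(C)=C/[C@@H](O)C/C(C)=C/CCc1ccoc1)[C@]1(C)CCC(=O)O1` gives 30 nM
Compound 3 `CC(=O)O[C@H](/C=C(\C)CC[C@@H](O)[C@]1(C)CCC(=O)O1)C/C(C)=C/CCc1ccoc1` gives 200 nM

Compound 3 (200 nM) has the highest number of the three and is the weakest of them, compared with compound 1 (40 nM) and compound 2 (30 nM). It already carries one acetyl but keeps one free hydroxy group. Compound 4 `CC(=O)O[C@H](/C=C(\C)CC[C@@H](OC(C)=O)[C@]1(C)CCC(=O)O1)C/C(C)=C/CCc1ccoc1` differs from compound 3 by a single change (acetyl in place of hydrogen on an oxygen on a saturated carbon): that remaining hydroxy becomes acetoxy, an acetyl in place of hydrogen on an oxygen on a saturated carbon.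

Among the measured compounds shown here, two measured steps bear on this change. One puts an acetyl on the same oxygen as here (a 1.3-fold lower number from compound 1 to compound 2 (0.12 log units; within the scatter)), so it is the closer guide. The other puts an acetyl on the other hydroxy group (a 5.0-fold higher number from compound 1 to compound 3 (0.70 log units; beyond the scatter)). That acetyl is already present before this new change, so this step says little about it. The data do not show whether the closer guide holds once the other acetyl is present. Even so, no shift beyond the scatter is expected in this assay, only a slight drift towards a lower number (a 1.3-fold lower number from compound 3 to compound 4 (0.12 log units; within the scatter)). Compound 4 is estimated at 150 nM with an expected range from 60 nM to 400 nM in this assay.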

Compound 4, half-maximal inhibitory concentration: 600 nM
Compound 4: middle estimate off by 4.0-fold (0.60 log units), on the low side; the whole stated range lies below it.
By their numbers in this assay, from the lowest: compounds 2 and 1 (each within the scatter of the next); then compound 3; then compound 4.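

In this assay, turning the remaining hydroxy into acetoxy is not a neutral change once the other hydroxy already carries an acetyl, with a 3.0-fold higher number from compound 3 to compound 4 (0.48 log units; beyond the scatter). This oxygen therefore accepts an acetyl with no shift beyond the scatter only while the other hydroxy stays free, so the outcome at one oxygen depends on the state of the other, as the same change on two cores shows: the same change on two cores in this assay, a 1.3-fold lower number (0.12 log units; within the scatter) from compound 1 to compound 2 and a 3.0-fold higher number (0.48 log units; beyond the scatter) from compound 3 to compound 4, 4.0-fold (0.60 log units) apart, beyond the scatter of two such steps Seen from the other oxygen, the picture agrees, because an acetyl there raises the number further when the first oxygen is already acetylated, with a 20-fold higher number from compound 2 to compound 4 (1.30 log units; beyond the scatter), and the two steps compare as follows: the same change on two cores in this assay, a 5.0-fold higher number (0.70 log units; beyond the scatter) from compound 1 to compound 3 and a 20-fold higher number (1.30 log units; beyond the scatter) from compound 2 to compound 4, 4.0-fold (0.60 log units) apart, beyond the scatter of two such steps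

On these data alone, these compounds carry only hydrogen or acetyl on the two oxygens, so it stays open whether a longer ester such as butanoyl would follow the same pattern. Also open, as far as these compounds go, is whether what matters in compound 4 is the loss of both free hydroxy groups or the presence of both acetyl groups, and a methyl ether on these oxygens could help separate the two.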